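The source may report more compounds than this note shows. Statements on the series, on what has been measured and on what is new or still open speak of the compounds shown alone.

Measured compounds:
- compound 1, `Cc1ccc(NC(=O)C2CCN(C/C=C/c3ccccc3)CC2)cc1`: 29600 nM
- compound 2, `CCCc1ccc(NC(=O)C2CCN(C/C=C/c3ccccc3)CC2)cc1`: 9470 nM

Compound 1 has the structure `Cc1ccc(NC(=O)C2CCN(C/C=C/c3ccccc3)CC2)cc1`. Among the compounds with values here, in a functional assay on A549 cells (Homo sapiens) for inhibition, read by MTT assay, with a stated time of 72 h (a lower number here means a stronger inhibitor, a higher number a weaker inhibitor), compound 1 gives 29600 nM, the highest of the two numbers measured so far. Within the data shown here, its nearest neighbour is compound 2, `CCCc1ccc(NC(=O)C2CCN(C/C=C/c3ccccc3)CC2)cc1`, which in this assay gives 9470 nM; the one measured step runs a 3.1-fold lower number from compound 1 to compound 2 (0.49 log units; beyond the scatter).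

Compound 3, `O=C(Nc1ccc(F)c(Br)c1)C1CCN(C/C=C/c2ccccc2)CC1`, has not yet been measured. It differs from compound 1 in one place: 3-bromo-4-fluorophenyl in place of 4-methylphenyl on an amide-type nitrogen.

Among the measured compounds shown here, no measured step concerns this exchange. For the measured compounds named here, the only step known, from compound 1 to compound 2, changes the same aryl group in another way and is modest in size, so it shows only that an alteration of this group can move the number by a modest amount. On this basis the author expects a step in this assay of about a 1.5-fold lower number from compound 1 to compound 3 (0.17 log units; within the scatter), with little confidence in its direction. For compound 3 the estimate is 20000 nM, within a range from 5000 nM to 80000 nM.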

Compound 3, half-maximal inhibitory concentration: 11700 nM
Compound 3: middle estimate off by 1.7-fold (0.23 log units), on the high side; low and high end bracket the measured number.
By their numbers in this assay, from the lowest: compounds 2 and 3 (each within the scatter of the next); then compound 1.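

In this assay, 3-bromo-4-fluorophenyl in place of 4-methylphenyl on the amide-type nitrogen gives a 2.5-fold lower number from compound 1 to compound 3 (0.40 log units; beyond the scatter), so this position responds to a change of ring substituents as well as to the lengthening of a chain, and compound 1 now stands apart from both of the other compounds by a margin beyond the scatter. Set against the 4-propylphenyl group, the same 3-bromo-4-fluorophenyl group gives a 1.2-fold higher number from compound 2 to compound 3 (0.09 log units; within the scatter), so these two quite different groups cannot be told apart in this assay, and the data offer no ranking between them. Nothing available explains why either group gives a lower number than 4-methylphenyl.

The compounds shown leave open whether the 3-bromophenyl or the 4-fluorophenyl group alone would account for the step, and how a ring carrying an amine, a carboxylic acid or a chain longer than propyl would compare. They also leave open how far any of these numbers would move with a change elsewhere, as all three compounds share the rest of the core unchanged.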